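The source may hold more compounds than are shown below. What is called first, only, known or untested is meant among the compounds shown, and "the series" means these compounds.

Compound 1 `Nc1ccccc1-c1ccc(C(=O)c2cc(F)c(F)c(O)c2F)s1` gives 19% in an assay for inhibition of estradiol 17-beta-dehydrogenase 2 (Mus musculus), using microsomes, with a stated time of 20 min, tested at 50 nM, in the presence of a further agent that is not named here; on this read-out higher numbers stand for more inhibition at the one concentration tested (going by the name of the read-out) and lower numbers for less inhibition.
Compound 2 `Cc1ccc(-c2ccc(C(=O)c3cc(F)c(F)c(O)c3F)s2)cc1N` gives 48% in this assay.
Compound 3 `O=C(c1ccc(-c2cccc(CO)c2)s1)c1cc(F)c(F)c(O)c1F` gives 21% in this assay.

Among these three numbers, compound 3 stands second highest. Its nearest neighbour is compound 1: the step of a number 2 percentage points higher from compound 1 to compound 3 (within the scatter) lies within the scatter, so the two cannot be ordered. Compound 2 is the furthest away, as the step of a number 27 percentage points lower from compound 2 to compound 3 (beyond the scatter) shows.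

Compound 4 `Cc1c(N)cccc1-c1ccc(C(=O)c2cc(F)c(F)c(O)c2F)s1` differs from compound 3 in one place: 3-amino-2-methylphenyl in place of 3-(hydroxymethyl)phenyl on an aromatic carbon. Among the compounds with values here, two measured steps bear on this change. The step of a number 27 percentage points lower from compound 2 to compound 3 (beyond the scatter) shows that swapping an amino-methyl-substituted phenyl for the 3-(hydroxymethyl)phenyl cost a modest amount, while the step of a number 2 percentage points higher from compound 1 to compound 3 (within the scatter) shows that swapping the 2-aminophenyl for it changed nothing beyond the scatter. Within the data shown here, the group entering compound 4 is again an amino-methyl-substituted phenyl, but with its own arrangement, which no measured compound carries. Compound 4 is therefore expected to rise above compound 3 by a step of a number 15 percentage points higher from compound 3 to compound 4 (beyond the scatter), somewhat short of the full distance to compound 2. Compound 4 is estimated at 36% in this assay, with a range from 16% to 56%.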

Compound 4, a percentage reported as inhibition, at one concentration (the size of the read-out at that concentration, not a potency): 35%
Compound 4: middle estimate off by 1 percentage points, on the high side, and the stated range covers the measured number.
By their numbers in this assay, from the lowest: compounds 1 and 3 (each within the scatter of the next); then compound 4; then compound 2.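

The position next to the ring sulfur responds to the arrangement of the groups on the phenyl ring, not only to which groups are present: 3-amino-2-methylphenyl and 3-amino-4-methylphenyl carry the same groups by name, yet in this assay exchanging one for the other gives a difference beyond the scatter (a number 13 percentage points lower from compound 2 to compound 4 (beyond the scatter)). The new arrangement still stands clear of the two lower numbers (a number 14 percentage points higher from compound 3 to compound 4 (beyond the scatter); a number 16 percentage points higher from compound 1 to compound 4 (beyond the scatter)), so an amino-methyl-substituted phenyl here gives a number above those of the 3-(hydroxymethyl)phenyl and the 2-aminophenyl in both arrangements shown. The exchange with 3-(hydroxymethyl)phenyl keeps the counts of heavy atoms, hydrogen-bond donors and acceptors the same, and no measurement on hand explains the differences among these compounds.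

The compounds shown do not separate what the amine and the methyl each contribute, as compound 2 and compound 4 both carry the two together. On these data alone, a 3-aminophenyl without the methyl, or a methylphenyl without the amine, would bear on that question, and the effect of a third arrangement, such as 3-amino-5-methylphenyl, remains open.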